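A few compounds are considered here, and "the series" means these few. Any claim that something is new, unique, unknown or untested is made for them only; others in the source may bear on it.

Compound 1 `O=C(Nc1nnn[nH]1)c1cc(=O)c2ccccc2o1` carries a 1H-tetrazol-5-yl group on its amide nitrogen. In a functional assay on the whole organism for inhibition, with Rattus norvegicus as the target, with a stated time of 30 min, at a dose of 1 mg/kg by the intravenous route (on this read-out lower numbers stand for less inhibition and higher numbers for more inhibition at the one dose given (going by the name of the read-out)), compound 1 gives 100%. Compound 2 `N#Cc1ccc2oc(C(=O)Nc3nnn[nH]3)cc(=O)c2c1` gives 100% in this assay, and the step of no change at the digits printed from compound 1 to compound 2 (within the scatter) shows nothing beyond the scatter, so compound 1 and compound 2 together stand as the highest of the three numbers. Compound 3 `Cc1c(C(=O)Nc2nnn[nH]2)oc2ccccc2c1=O` gives 70% in this assay, and the step of a number 30 percentage points lower from compound 1 to compound 3 (beyond the scatter) is a modest drop. Compound 4 `O=C(Nc1nc[nH]n1)c1cc(=O)c2ccccc2o1` has not yet been measured. It differs from compound 1 in one place: 1H-1,2,4-triazol-3-yl in place of 1H-tetrazol-5-yl on an amide-type nitrogen. Going by the values given here, both measured steps replace a hydrogen on an aromatic carbon of the shared core; neither changes the group on the amide nitrogen, so no measured step bears directly on this change. The estimate rests mainly on compound 1 and its value 100%, with a wide range allowed for the untested change. Compound 4 is expected to give 70% in this assay, between 30% and 100%. The expected step is a number 30 percentage points lower from compound 1 to compound 4 (beyond the scatter), a drop that may or may not exceed the scatter.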

Compound 4, a percentage reported as inhibition, in the whole organism at one dose (the size of the read-out at that dose, not a potency): 0%
For compound 4 the middle estimate is 70 percentage points above the measured one, and the stated range ends above it.
By their numbers in this assay, from the lowest: compound 4; then compound 3; then compounds 1 and 2 (each within the scatter of the next).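

In this assay, the group on the amide nitrogen carries far more weight than either core change seen so far: 1H-1,2,4-triazol-3-yl in place of 1H-tetrazol-5-yl gives a number 100 percentage points lower from compound 1 to compound 4 (beyond the scatter), the largest step shown. The two groups have the same count of heavy atoms and of hydrogen-bond donors, and the entering ring has a carbon where the leaving ring has a nitrogen, so a small change in this ring is enough to take the read-out from the top of the series to the bottom. Nothing in hand explains this loss.

The compounds shown leave open how a carboxylic acid or a phenyl ring on the amide nitrogen would fare. They also leave open whether a nitrile or methyl group on the core would change the read-out of the triazole compound.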